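The compounds below may be only part of what the source reports. "The series", "measured", "known", "first", "only" and "open" are said of these compounds alone.

Measured compounds and their values:
Compound 1 `Cc1nc(C)c(COc2ccccc2C(=O)O)nc1C`: 20%
Compound 2 `Cc1nc(C)c(COC(=O)CCCC[C@@H]2CCSS2)nc1C`: 206%
Compound 3 `Cc1nc(C)c(COc2ccc3ccc(=O)oc3c2)nc1C`: 46.6%

All three share the same core and were tested in a functional assay on ECV-304 cells (Homo sapiens), read by MTT assay, with stated times of 24 h and 12 h, tested at 100 uM; a higher number here means a stronger effect of the compound at the concentration tested, a lower number a weaker effect. Compound 3 gives 46.6%, the second highest of the three numbers. Its nearest neighbour is compound 1, which gives 20%, a lower number beyond the scatter. Furthest away is compound 2, which gives 206%, a far higher number, again beyond the scatter.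

Compound 4 `Cc1nc(C)c(COc2ccc3c(C)cc(=O)oc3c2)nc1C` has not yet been measured in this assay . It differs from compound 3 in one place: methyl in place of hydrogen on an aromatic carbon.

For the measured compounds named here, no two measured compounds differ by a single such change, so the size of this step cannot be read from the numbers at hand. With only a methyl entering in place of a hydrogen, the expected step of a number 3.4 percentage points higher from compound 3 to compound 4 (within the scatter) is small, in either direction, and quite possibly none beyond the scatter. Compound 4 is therefore expected to give 50%, with a likely range from 25% to 85%.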

Compound 4, a percentage reported as activity, at one concentration (the size of the read-out at that concentration, not a potency): 36.6%
Beside the measured number, compound 4's estimate is 13.4 percentage points above it; the measured number falls inside the stated range.
By their numbers in this assay, from the lowest: compound 1; then compounds 4 and 3 (each within the scatter of the next); then compound 2.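

In this assay, for the compounds shown here, a methyl in place of hydrogen on the aromatic carbon opposite the ring oxygen gives the first single-change step in this set: a number 10 percentage points lower from compound 3 to compound 4 (within the scatter). Going by these compounds alone, the numbers for these two compounds cannot be told apart, so at this position, one added methyl leaves no effect that stands clear of the usual scatter, something the earlier compounds, none differing in just one place, could not show. Nothing measured here bears on the reason for this result.

On these data alone, whether a larger or different group at this position, such as an ethyl, a phenyl ring, an amine or a carboxylic acid, would give a step beyond the scatter remains open. Within the data shown here, compound 1 and compound 2 differ from these two in more than one place, so no steps to them can be read.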